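Cytotoxicity notes: one aryl swap carried to a second core

The source may hold more compounds than are shown below. What is called first, only, known or untested is meant among the compounds shown, and "the series" means these compounds.

Three members of the series have been measured in an ADME assay on HepG2 cells (Homo sapiens) for cytotoxicity, read by luminescence, CellTiter-Glo and ATP content, with a stated time of 72 h; a higher number here means that more compound is needed for the effect, a lower number that less compound is needed. Compound 1 `COc1ccc(F)cc1CNCCCNc1ccnc2cc(Cc3ccc(F)cc3Cl)ccc12` gives 2460 nM in this assay. Compound 2 `COc1ccc(F)cc1CNCCCNc1ccnc2cc(-c3cccc4ccccc34)ccc12` gives 16000 nM. Compound 3 `COc1cccc(CNCCCNc2ccnc3cc(Cc4ccc(F)cc4Cl)ccc23)c1O` gives 2350 nM.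

Compound 1 and compound 2 share everything except the group on the fused two-ring system: naphthalen-1-yl in place of 2-chloro-4-fluorobenzyl on an aromatic carbon. That change gave a 6.5-fold higher number from compound 1 to compound 2 (0.81 log units; beyond the scatter), so the naphthalen-1-yl compound needs more material for the effect in this assay.

Compound 1 and compound 3 differ only in the aryl group on the chain: 2-hydroxy-3-methoxyphenyl in place of 5-fluoro-2-methoxyphenyl on a saturated chain carbon bound to an amine nitrogen. Here the values show a 1.0-fold lower number from compound 1 to compound 3 (0.02 log units; within the scatter), so the two cores read the same within the usual spread of this assay.

Compound 4 `COc1cccc(CNCCCNc2ccnc3cc(-c4cccc5ccccc45)ccc23)c1O` has not yet been measured. It stands to compound 3 as compound 2 stands to compound 1: naphthalen-1-yl in place of 2-chloro-4-fluorobenzyl on an aromatic carbon. The place of the change is described in the same words for both pairs, so it is the same change on a core that differs only by the aryl group on the chain.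

Given that the cores of compound 1 and compound 3 read alike, the step is expected to carry over: a 6.4-fold higher number from compound 3 to compound 4 (0.81 log units; beyond the scatter) is the expected shift, beside the measured 6.5-fold higher number from compound 1 to compound 2 (0.81 log units; beyond the scatter). Compound 4 is therefore estimated at 15000 nM in this assay, with a likely span from 6000 nM to 40000 nM. Two pairs are a thin basis, and a reported limit rather than a number cannot be ruled out.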

Compound 4, half-maximal effective concentration: 2520 nM
Estimate against measurement, compound 4: 6.0-fold (0.77 log units) above; measured number outside the range, below it.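

On the core of compound 3, naphthalen-1-yl in place of 2-chloro-4-fluorobenzyl gave a 1.1-fold higher number from compound 3 to compound 4 (0.03 log units; within the scatter), so in this assay the step seen on the core of compound 1 did not carry over: the same change on two cores in this assay, a 6.5-fold higher number (0.81 log units; beyond the scatter) from compound 1 to compound 2 and a 1.1-fold higher number (0.03 log units; within the scatter) from compound 3 to compound 4, 6.1-fold (0.78 log units) apart, beyond the scatter of two such steps

Read the other way, 2-hydroxy-3-methoxyphenyl in place of 5-fluoro-2-methoxyphenyl gave a 6.3-fold lower number from compound 2 to compound 4 (0.80 log units; beyond the scatter) with naphthalen-1-yl present, whereas the same swap made no readable difference with 2-chloro-4-fluorobenzyl present: the same change on two cores in this assay, a 1.0-fold lower number (0.02 log units; within the scatter) from compound 1 to compound 3 and a 6.3-fold lower number (0.80 log units; beyond the scatter) from compound 2 to compound 4, 6.1-fold (0.78 log units) apart, beyond the scatter of two such steps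

The two changes therefore do not act independently in these four compounds, and compound 2 is the one that stands apart, but a single set of four shows neither why the steps differ nor whether the same holds for any other pair of groups in the series.

Still open, as far as these compounds go, is whether a plain phenyl or a 2-naphthyl group on the aromatic carbon would follow compound 2 or compound 4 when paired with each chain aryl group. Also open, from the compounds shown here alone, is whether a 2-hydroxyphenyl or a 3-methoxyphenyl group alone, or a longer chain, would show the same dependence.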